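A few compounds are considered here, and "the series" means these few. Any claim that something is new, unique, unknown or untested is made for them only; others in the source may bear on it.

In a functional assay (aorta) with Rattus norvegicus as the target (on this read-out higher numbers stand for an effect only at larger amounts of compound and lower numbers for an effect already at smaller amounts), compound 1 `CC(C)NC1=NS(=O)(=O)c2cccnc2N1` gives 132 uM, compound 2 `O=S1(=O)N=C(NCC2CCCCC2)Nc2ncccc21` gives 45.7 uM, and compound 3 `O=S1(=O)N=C(NCc2ccccc2)Nc2ncccc21` gives 21.9 uM, the lowest of the three numbers. Compound 4 `C[C@@H](NC1=NS(=O)(=O)c2cccnc2N1)c1ccccc1` departs from compound 3 in a single place: methyl in place of hydrogen on a saturated chain carbon bound to an amine nitrogen and an aromatic carbon. In words, this is methyl in place of hydrogen on a saturated chain carbon bound to an amine nitrogen and an aromatic carbon.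

Among the measured compounds shown here, only one measured step bears on this change. It is a 2.1-fold lower number from compound 2 to compound 3 (0.32 log units; beyond the scatter), a modest step that exchanges cyclohexyl for phenyl on the same kind of chain carbon. For the measured compounds named here, no measured pair shows what adding methyl at this place does, so that modest step serves only as a rough guide to scale. A small shift in this assay is therefore expected, with no firm direction and nothing clearly beyond the scatter. The expected step is a 1.2-fold lower number from compound 3 to compound 4 (0.09 log units; within the scatter). For compound 4, the estimated value is 18 uM, within an expected range from 6 uM to 55 uM.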

Compound 4, concentration for half-maximal effect: 9.9 uM
Estimate against measurement, compound 4: 1.8-fold (0.26 log units) above; measured number inside the range.
By their numbers in this assay, from the lowest: compound 4; then compound 3; then compound 2; then compound 1.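

In this assay, methyl in place of hydrogen on a saturated chain carbon bound to an amine nitrogen and an aromatic carbon gives a 2.2-fold lower number from compound 3 to compound 4 (0.34 log units; beyond the scatter). The earlier pair showed only that exchanging cyclohexyl for phenyl on a chain carbon moves the number, whereas this step shows that the chain carbon itself responds to substitution, with an added methyl giving a lower number rather than a higher one. Nothing shown here gives a measured basis for explaining this shift.

The compounds shown leave open whether ethyl or hydroxymethyl in place of this methyl would lower the number further or reverse the step. They also leave open whether methyl at this place would have a similar effect with cyclohexyl in place of phenyl.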